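The source may report more compounds than this note shows. Statements on the series, on what has been measured and on what is new or still open speak of the compounds shown alone.

In a functional assay on P388 cells (Mus musculus) for antiproliferative activity (on this read-out higher numbers stand for weaker inhibition and lower numbers for stronger inhibition), compound 1 (`N#Cc1ccc(S(=O)(=O)Nc2cccc3c(Cl)c[nH]c23)cc1`) gives 1.4 ug/mL and compound 2 (`CS(=O)(=O)Nc1ccc(S(=O)(=O)Nc2cccc3c(Cl)c[nH]c23)cc1`) gives 1.6 ug/mL. These two numbers are all that has been measured so far, and they lie within the scatter of each other, so compound 2 stands level with compound 1. Compound 3 (`NS(=O)(=O)Cc1ccc(S(=O)(=O)Nc2cccc3c(Cl)c[nH]c23)cc1`) keeps the shared core and alters one group: sulfamoylmethyl in place of methanesulfonamido on an aromatic carbon. Sulfamoylmethyl comes in place of methanesulfonamido on an aromatic carbon, para to a large group. Among the measured compounds shown here, only one measured step bears on this change, a 1.1-fold higher number from compound 1 to compound 2 (0.06 log units; within the scatter), where methanesulfonamido came in place of cyano on an aromatic carbon and the number stayed within the scatter. One step is thin evidence, but it gives no reason to expect a real shift in this assay. The expected change is no change at the digits printed from compound 2 to compound 3 (within the scatter), which would be no step beyond the scatter. For compound 3 the estimated value is 1.6 ug/mL, within a range of 0.7 ug/mL to 3.5 ug/mL.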

Compound 3, half-maximal inhibitory concentration: 0.15 ug/mL
The estimate for compound 3 lay 11-fold (1.03 log units) above the measured number; the whole stated range lies above it.
By their numbers in this assay, from the lowest: compound 3; then compounds 1 and 2 (each within the scatter of the next).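

The earlier pair gave this position the look of one where the substituent hardly matters, but compound 3 shows otherwise in this assay: there is an 11-fold lower number from compound 2 to compound 3 (1.03 log units; beyond the scatter) even though the two groups have the same atoms, joined differently, and the same counts of hydrogen-bond donors and acceptors. The change also stands out against the nitrile, with a 9.3-fold lower number from compound 1 to compound 3 (0.97 log units; beyond the scatter), so on this aromatic carbon sulfamoylmethyl gives a lower number than either earlier group. Nothing in the data shown explains this shift.

Whether the effect is specific to sulfamoylmethyl remains open, as the compounds shown do not say how a plain sulfamoyl group, the longer sulfamoylethyl chain or a carboxylic acid would behave at this position. They also leave open whether an aminomethyl group would share any of the shift.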